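Dropping the 3-Chlorophenyl Group from Compound 1

The compounds below may be only part of what the source reports. "The series", "measured", "known", "first", "only" and "open" are said of these compounds alone.

Measured compounds:
Compound 1 `N#C/C(=C\c1cc(O)c(O)c([N+](=O)[O-])c1)C(=O)Nc1cccc(Cl)c1` gives > 100 ug/mL in a functional assay on BGC-823 cells (Homo sapiens) for antiproliferative activity, read by MTT assay (on this read-out lower numbers stand for stronger inhibition and higher numbers for weaker inhibition), which is a limit of the measurement rather than a number.
Compound 2 `COc1cc(/C=C(\C#N)C(=O)Nc2cccc(Cl)c2)cc([N+](=O)[O-])c1O` gives 26.1 ug/mL in this assay.

As far as these compounds go, compound 1 stands at the edge of what the measurement reports: the limit of > 100 ug/mL in this assay, at which 1 of the 2 values shown sits, so its true value is unknown beyond that limit. Among the measured compounds shown here, the only measured step is an at least 3.8-fold lower number from compound 1 to compound 2 (0.58 log units; beyond the scatter), and it concerns a methyl on an oxygen of the aromatic ring, a different place from the one changed here.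

Compound 3 `N#C/C(=C\c1cc(O)c(O)c([N+](=O)[O-])c1)C(N)=O` has not been measured. It differs from compound 1 by hydrogen in place of 3-chlorophenyl on an amide-type nitrogen. For the measured compounds named here, no measured step bears on a change at the amide nitrogen, so the data give no direction for it. Since compound 1 already sits at the limit, compound 3 is expected to stay near that limit, with a step that the limit leaves unreadable from compound 1 to compound 3 that is not expected to go beyond the scatter. For compound 3 the estimate in this assay is 150 ug/mL, with a range from 50 ug/mL to 400 ug/mL, and a real chance that only a limit is reported again.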

Compound 3, half-maximal inhibitory concentration: > 100 ug/mL
Compound 3 was reported as a limit; the forecaster's own chance of this, stated with the estimate: 70%; the middle value lies beyond the limit too.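

In this assay compound 3 gives > 100 ug/mL as a limit and not a number. Among the compounds shown here, compound 1 sits at the same limit, so no step between compound 1 and compound 3 can be read: the limit of > 100 ug/mL in this assay, at which 2 of the 3 values shown sit. As far as these compounds go, whether hydrogen in place of 3-chlorophenyl on the amide-type nitrogen changes the activity at all stays open.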